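Working notes on cytotoxicity across four related compounds

A few compounds are considered here, and "the series" means these few. Any claim that something is new, unique, unknown or untested is made for them only; others in the source may bear on it.

Measured compounds, values in an ADME assay on WEHI13 cells (Mus musculus) for cytotoxicity, read by MTT assay; on this read-out lower numbers stand for stronger inhibition and higher numbers for weaker inhibition:
compound 1 `Cc1c(CNC(C)(C)C)cc(-c2ccccc2)n1Nc1ccnc2cc(Cl)ccc12` — in this assay compound 1 gives "not determined" (no result reported)
compound 2 `Cc1c(CNC[C@@H]2CCCN3CCCC[C@H]23)cc(-c2ccccc2)n1Nc1ccnc2cc(Cl)ccc12` — in this assay compound 2 gives 7440 nM
compound 3 `Cc1cc(CN2CCCC2)c(C)n1Nc1ccnc2cc(Cl)ccc12` — in this assay compound 3 gives "not determined" (no result reported)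

Compound 3 has no number in this assay, and one further compound of the set, compound 1, is likewise without a number. The only figure for the whole set is that of compound 2. Compound 3 therefore cannot be placed on the numbers; there is nothing to rank it against.

Compound 4 `Cc1c(CN2CCCC2)cc(-c2ccccc2)n1Nc1ccnc2cc(Cl)ccc12` is the next member and still has to be measured in this assay. It differs from compound 3 in one place: phenyl in place of methyl on an aromatic carbon. Among the measured compounds shown here, no step between measured compounds is available to calibrate such a change, so the size of the step from compound 3 to compound 4 in this assay cannot be read from the data; no shift beyond the usual scatter is expected in either direction. Based on compound 2, which gives 7440 nM, compound 4 is expected to show weak inhibition, estimated at 8000 nM with a range of 2500 nM to 25000 nM.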

Compound 4, half-maximal inhibitory concentration: 3880 nM
Beside the measured number, compound 4's estimate is 2.1-fold (0.31 log units) above it; the range from low to high includes it.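

Among the compounds shown here, with phenyl on the aromatic carbon next to the ring nitrogen, the first comparison becomes possible in this assay: a 1.9-fold lower number from compound 2 to compound 4 (0.28 log units; within the scatter), so the (pyrrolidin-1-yl)methyl group of compound 4 and the larger two-ring group of compound 2 cannot be told apart on this read-out. The steps involving compound 1 or compound 3, including phenyl in place of methyl, cannot be read, as neither compound has a number. Nothing available bears on the origin of this result.

From the compounds shown here alone, whether phenyl at this aromatic carbon matters to the read-out remains open, as does how a hydrogen, an ethyl chain or a methoxy group would read there. Also open, going by these compounds, is how a dimethylamino group would read on the saturated chain carbon.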